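A Fluorophenyl Swap and Rat Liver Clearance

The source may hold more compounds than are shown below. What is called first, only, known or untested is meant among the compounds shown, and "the series" means these compounds.

Measured so far in an ADME assay on microsomes from liver (Rattus norvegicus) for pharmacokinetics; on this read-out lower numbers stand for slow clearance and higher numbers for fast clearance:
- Compound 1 `Cn1cc(-c2ncc(C#N)c(N3C[C@@H]4C[C@H]3CN4S(=O)(=O)C3CC3)n2)cn1`: < 36 mL/min/kg
- Compound 2 `C[C@@H]1CN(c2nc(-c3cnn(C)c3)ncc2C#N)CCN1C(=O)C1(C)CC1`: < 36 mL/min/kg

Compound 1 has no exact reading, only the limit < 36 mL/min/kg. Compound 2 also has only a limit, < 36 mL/min/kg. The whole picture so far is the limit of < 36 mL/min/kg in this assay, at which 2 of the 2 values shown sit. Neither compound can therefore be placed ahead of the other, and compound 1 enters this comparison without a precise starting point.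

Compound 3 `Cn1cc(-c2ncc(C#N)c(N3C[C@@H]4C[C@H]3CN4c3cccc(F)c3)n2)cn1` keeps the core of compound 1 but carries 3-fluorophenyl in place of cyclopropylsulfonyl on an amine nitrogen in a ring. Going by the values given here, no two measured compounds differ in just one place, so no measured step shows how large this change might be. The expectation in this assay is therefore a judgement based on the structural change alone: a move towards faster clearance, somewhat beyond the usual scatter, although another limit result remains possible. The expected step is an at least 1.6-fold higher number from compound 1 to compound 3 (0.22 log units; that floor lies within the scatter). For compound 3 the estimated clearance is 60 mL/min/kg, with an expected range from 30 mL/min/kg to 120 mL/min/kg.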

Compound 3, clearance: 1090 mL/min/kg
Compound 3: the middle estimate sits 18-fold (1.26 log units) below what was measured; the whole stated range lies below it.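

Until this point, this assay had given only limits, and nothing showed whether the group on this nitrogen of the shared core could move clearance at all: the limit of < 36 mL/min/kg in this assay, at which 2 of the 3 values shown sit.

Compound 3 gives the first exact reading, and it shows that this position can matter greatly: putting 3-fluorophenyl in place of cyclopropylsulfonyl on an amine nitrogen in a ring gives an at least 30-fold higher number from compound 1 to compound 3 (1.48 log units; beyond the scatter). Compound 1 stands at a limit and not at a number, and the step measured from it is a floor, with the true gap possibly wider still.

The single swap removes one whole group and brings in another, and the compounds shown cannot tell whether the step comes from losing cyclopropylsulfonyl, from gaining the aromatic ring, or from the fluorine on that ring. On these data alone, a plain phenyl without fluorine or a small acetyl group on the same nitrogen of the core of compound 1 would begin to separate these possibilities, and whether a similar swap would have a similar effect on the different core of compound 2 also remains open.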